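The source may report more compounds than this note shows. Statements on the series, on what has been measured and on what is new or still open speak of the compounds shown alone.

Working notes on the series, cytotoxicity on HEL cells.

Compound 3 `Cc1cn([C@@H]2O[C@H](CO[Si](C)(C)C(C)(C)C)[C@@]3(OS(=O)(=O)C=C3NC(N)=O)[C@H]2O[Si](C)(C)C(C)(C)C)c(=O)n(C)c1=O` carries a carbamoyl group on the amine nitrogen of the shared core. In a functional assay on HEL cells (Homo sapiens) for cytotoxicity, read by microscopy (a lower number here means that less compound is tolerated, a higher number that more compound is tolerated), compound 3 gives 16000 nM. It stands level with compound 2 `CCOC(=O)NC(=O)NC1=CS(=O)(=O)O[C@@]12[C@@H](CO[Si](C)(C)C(C)(C)C)O[C@@H](n1cc(C)c(=O)n(C)c1=O)[C@@H]2O[Si](C)(C)C(C)(C)C`, which in this assay gives 16000 nM; together these are the lowest of the three numbers measured. The step of no change at the digits printed from compound 2 to compound 3 (within the scatter) lies within the scatter. Compound 1 `Cc1cn([C@@H]2O[C@H](CO[Si](C)(C)C(C)(C)C)[C@@]3(OS(=O)(=O)C=C3NCC(=O)O)[C@H]2O[Si](C)(C)C(C)(C)C)c(=O)n(C)c1=O` is the furthest from compound 3: in this assay compound 1 gives 300000 nM, and the step of a 19-fold lower number from compound 1 to compound 3 (1.27 log units; beyond the scatter) is large, as is the parallel step a 19-fold lower number from compound 1 to compound 2 (1.27 log units; beyond the scatter).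

Compound 4 `Cc1cn([C@@H]2O[C@H](CO[Si](C)(C)C(C)(C)C)[C@@]3(OS(=O)(=O)C=C3NCC(=O)C(=O)O)[C@H]2O[Si](C)(C)C(C)(C)C)c(=O)n(C)c1=O` has not yet been measured. Its change from compound 3 is (carboxycarbonyl)methyl in place of carbamoyl on an amine nitrogen. The step that bears on this is the one from carboxymethyl to carbamoyl, a 19-fold lower number from compound 1 to compound 3 (1.27 log units; beyond the scatter): compound 4 returns a carboxylic-acid-bearing chain to the same amine nitrogen, so a step back toward the number of compound 1 is expected rather than no change. The step from compound 2 to compound 3 carries no information on this change.

Compound 4 is therefore expected to show a 9.4-fold higher number from compound 3 to compound 4 (0.97 log units; beyond the scatter) in this assay, a higher number. The estimate for compound 4 is 150000 nM, with a range from 30000 nM to 400000 nM.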

Compound 4, minimum cytotoxic concentration: 400000 nM
Estimate against measurement, compound 4: 2.7-fold (0.43 log units) below; measured number inside the range.
By their numbers in this assay, from the lowest: compounds 2 and 3 (each within the scatter of the next); then compounds 1 and 4 (each within the scatter of the next).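

The (carboxycarbonyl)methyl chain on the amine nitrogen gives a large separation from the carbamoyl group, with a 25-fold higher number from compound 3 to compound 4 (1.40 log units; beyond the scatter) in this assay, and an equally large one from the (ethoxycarbonyl)carbamoyl group, with a 25-fold higher number from compound 2 to compound 4 (1.40 log units; beyond the scatter) in the same read-out. Going by these compounds alone, the added carbonyl does not separate the new chain from the carboxymethyl chain, since a 1.3-fold higher number from compound 1 to compound 4 (0.12 log units; within the scatter) in this assay stays within the scatter, so across these four compounds the numbers fall into two groups: compounds 1 and 4 with the chains ending in carboxy, and compounds 2 and 3 with the carbamoyl-type groups, with no compound going against this split. No measurement shown here accounts for this split.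

The compounds shown leave open whether the free carboxylic acid at the end of the chain is what sets compounds 1 and 4 apart, or whether its methyl ester or primary amide would fall with them. A longer chain ending in carboxy, or a chain ending in an amine, on the same nitrogen also remains to be placed against these two groups.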